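Dichloro analogue on the ester-imine core: expected inhibition

The compounds below may be only part of what the source reports. "The series", "measured", "known", "first", "only" and "open" are said of these compounds alone.

Compound 1 `O=C(O)C(=O)/C=C(\O)c1ccccc1Cl` carries one chloro group on its aromatic ring, and compound 2 `O=C(O)C(=O)/C=C(\O)c1cccc(Cl)c1Cl` carries a second. In an assay for inhibition of kynurenine 3-monooxygenase (Rattus norvegicus), tested at 10 uM (a higher number here means more inhibition at the concentration tested (going by the name of the read-out), a lower number less inhibition), compound 1 gives 33%, and compound 2 gives 33%. The step of no change at the digits printed from compound 1 to compound 2 (within the scatter) is chloro in place of hydrogen on an aromatic carbon: the added chloro brings no gain at the concentration tested.

Compound 3 `COC(=O)C(=N)/C=C(\O)c1ccccc1Cl` rests on a different core; how that core differs from the core of compound 1 is not broken down here. In this assay compound 3 gives 31%, a number within the scatter of both compound 1 and compound 2, so no order among the three can be read from these values.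

Compound 4 `COC(=O)C(=N)/C=C(\O)c1cccc(Cl)c1Cl` has not yet been measured. It differs from compound 3 by chloro in place of hydrogen on an aromatic carbon. This is the same kind of change as that from compound 1 to compound 2, though not the same: in compound 4 the entering chloro sits meta to a group of 9 heavy atoms, whereas in compound 2 it sits meta to a group of 8 heavy atoms.

Among the measured compounds shown here, the expectation for compound 4 rests on the single measured instance of this change, no change at the digits printed from compound 1 to compound 2 (within the scatter), together with the value of compound 3, 31%. The step from compound 3 to compound 4 is expected to be no change at the digits printed from compound 3 to compound 4 (within the scatter), essentially flat. Compound 4 is therefore estimated at 31% in this assay, with the plausible range running from 21% to 41%.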

Compound 4, a percentage reported as inhibition, at one concentration (the size of the read-out at that concentration, not a potency): 33%
Estimate against measurement, compound 4: 2 percentage points below; measured number inside the range.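

In this assay, chloro in place of hydrogen on an aromatic carbon, ortho to a chloro group, gives a number 2 percentage points higher from compound 3 to compound 4 (within the scatter), and this step agrees with the one seen on the core of compound 1: the same change on two cores in this assay, no change at the digits printed (within the scatter) from compound 1 to compound 2 and a number 2 percentage points higher (within the scatter) from compound 3 to compound 4, 2 percentage points apart, within the scatter of two such steps. On these two cores, the change therefore carries over as a flat step, and the core of compound 1 and the core of compound 3 give the same reading of it within the scatter. Among the compounds shown here, this does not show that the change is without effect on other cores or at other concentrations: the comparison rests on only two pairs, each read at a single concentration, so a stronger or weaker effect at other concentrations cannot be excluded.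

The compounds shown leave open whether another group at this place, such as a methoxy group, an amine or a nitrile, would move the number beyond the scatter, and whether chloro on another carbon of the ring would stay as flat. They also leave open which part of the difference between the two cores matters, if any does, as the two cores differ in more than one place.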